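A few compounds are considered here, and "the series" means these few. Any claim that something is new, unique, unknown or untested is made for them only; others in the source may bear on it.

In a functional assay on MDA-MB-231 cells (Homo sapiens) for cytotoxicity, read by MTT assay, with a stated time of 72 h (a lower number here means a stronger inhibitor, a higher number a weaker inhibitor), compound 3 `CN(C)Cc1ccc2nc(NC(=O)N/N=C/c3cn(Cc4ccccc4)c4ccccc34)sc2c1` gives 1340 nM. Compound 1 `CCN(CC)Cc1ccc2nc(NC(=O)N/N=C/c3cn(Cc4cccc(Cl)c4)c4ccccc34)sc2c1` gives 2050 nM and compound 2 `CCN(CC)Cc1ccc2nc(NC(=O)N/N=C/c3cn(Cc4ccc(C)cc4)c4ccccc34)sc2c1` gives 2010 nM, so all three numbers lie within the usual scatter of one another. Compound 4 `CCN(CC)Cc1ccc2nc(NC(=O)N/N=C/c3cn(Cc4ccccc4)c4ccccc34)sc2c1` differs from compound 3 in one place: diethylamino in place of dimethylamino on a saturated chain carbon bound to an aromatic carbon. Among the compounds with values here, no measured step covers this change directly. The only one, a 1.0-fold lower number from compound 1 to compound 2 (0.01 log units; within the scatter), concerns another group and stays within the scatter. Compound 1 and compound 2 do carry diethylamino, but they also differ from compound 3 elsewhere. The expected step, a 1.3-fold higher number from compound 3 to compound 4 (0.10 log units; within the scatter), therefore stays within the scatter in this assay. For compound 4 the estimated value is 1700 nM, with an expected range of 1000 nM to 2900 nM.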

Compound 4, half-maximal inhibitory concentration: 1470 nM
For compound 4 the middle estimate is 1.2-fold (0.06 log units) above the measured one; measured number inside the range.
By their numbers in this assay, from the lowest: compounds 3, 4, 2 and 1 (each within the scatter of the next).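

Read directly in this assay, diethylamino in place of dimethylamino on a saturated chain carbon bound to an aromatic carbon changes little (a 1.1-fold higher number from compound 3 to compound 4 (0.04 log units; within the scatter)). Within the data shown here, compound 4 also allows the first reading of the chloro and methyl groups against hydrogen on an aromatic carbon, and neither step leaves the scatter (a 1.4-fold lower number from compound 1 to compound 4 (0.14 log units; within the scatter); a 1.4-fold lower number from compound 2 to compound 4 (0.14 log units; within the scatter)). No evidence is available that bears on these small steps.

Still open, going by these compounds, is whether a cyclic amine such as piperidine or morpholine at this place would give a step beyond the scatter. The same question stands for a carboxylic acid there.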